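Azetidine amide in place of pyrimidinylmethyl amide

The compounds below may be only part of what the source reports. "The series", "measured", "known", "first", "only" and "open" are said of these compounds alone.

The series is followed in an assay for inhibition of 6-phosphofructo-2-kinase/fructose-2,6-bisphosphatase 3 (Homo sapiens), read by ADP-Glo, with a stated time of 2 h; on this read-out higher numbers stand for weaker inhibition and lower numbers for stronger inhibition. Compound 1 `Cn1ccc2ccc(-c3cc(Nc4ccccc4S(=O)(=O)N4CCOCC4)cc4nccnc34)cc21` gives 36 nM there. For the measured compounds named here, compound 2 `Cn1ccc2ccc(-c3cc(Nc4cnccc4C(=O)NCc4cncnc4)cc4nccnc34)cc21` gives 106 nM in this assay, the higher of the two numbers so far; the gap to compound 1 lies beyond the usual scatter of repeated measurements, and no further pairs of measured compounds are available to calibrate any single change. Compound 3 `CC(=O)N1CC(NC(=O)c2ccncc2Nc2cc(-c3ccc4ccn(C)c4c3)c3nccnc3c2)C1` is not yet measured in this assay. It differs from compound 2 by 1-acetylazetidin-3-yl in place of (pyrimidin-5-yl)methyl on an amide-type nitrogen. Going by the values given here, no measured step of this kind exists in the set, so the expected step from compound 2 to compound 3 in this assay is put at a 1.1-fold higher number from compound 2 to compound 3 (0.05 log units; within the scatter), that is, none beyond the scatter, with either direction about equally open. On that basis compound 3 is estimated to give 120 nM in this assay, with a range from 45 nM to 320 nM.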

Compound 3, half-maximal inhibitory concentration: 73 nM
For compound 3 the middle estimate is 1.6-fold (0.22 log units) above the measured one; low and high end bracket the measured number.
By their numbers in this assay, from the lowest: compound 1; then compounds 3 and 2 (each within the scatter of the next).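

In this assay, 1-acetylazetidin-3-yl in place of (pyrimidin-5-yl)methyl on the amide-type nitrogen gives a 1.5-fold lower number from compound 2 to compound 3 (0.16 log units; within the scatter) and so leaves the read-out within the scatter. At this position, the six-membered aromatic ring with its hetero atoms can therefore give way to a four-membered non-aromatic ring carrying an acetyl group, at least in this one exchange. No supporting measurement bears on why the two groups read alike.

Going by these compounds, whether the acetyl group matters remains open, as does the outcome with an azetidine lacking it, a morpholine or a simple methyl on the same amide nitrogen. For the compounds shown here, compound 1 differs from compound 3 in more than one place, so no step between them can be read.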